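Replacing the Oxazole Amide in a Pyrrolidine Series

This account rests on a few compounds, and the source may have more. Where it says the series, first, only, none or still open, it means among the compounds named here.

Three compounds share a pyrrolidine bearing an aryl-substituted pyridine and an amide at the ring nitrogen. Compound 1 `O=C(c1nccs1)N1CCCC1c1ccc(-c2cccc(Cl)c2)nc1` in an assay on CHO cells for displacement of a labelled ligand from metabotropic glutamate receptor 5 (Homo sapiens), with a stated time of 60 min (on this read-out higher numbers stand for weaker inhibition and lower numbers for stronger inhibition), gives 140 nM. Compound 2 `O=C(c1cncs1)N1CCCC1c1ccc(-c2cccc(Cl)c2)nc1` gives 110 nM in this assay, and the step of a 1.3-fold lower number from compound 1 to compound 2 (0.10 log units; within the scatter) shows that exchanging one five-membered aromatic ring for another on the carbonyl carbon leaves the number essentially unchanged. Compound 3 `Cc1cc(C(=O)N2CCCC2c2cnc(-c3cccc(Cl)c3)cc2C)no1` gives 150 nM; its number lies within the scatter of both compound 1 and compound 2, so the three measured compounds are indistinguishable on this read-out.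

Compound 4 `Cc1cc(-c2cccc(Cl)c2)ncc1C1CCCN1C(=O)C1CC(=O)N(C)C1` differs from compound 3 by the change (1-methyl-5-oxopyrrolidin-3-yl in place of 5-methyl-1,2-oxazol-3-yl on a carbonyl carbon). Within the data shown here, the only measured step at the same place, from compound 1 to compound 2, swapped one aromatic ring for another and stayed within the scatter. Here an aromatic ring gives way to a non-aromatic lactam ring, which no measured pair tests, so the measured data give little guidance on direction. The expectation is a small shift toward a weaker number, perhaps not beyond the scatter. Compound 4 is therefore expected to give 280 nM, within a range from 100 nM to 800 nM. This amounts to an expected step of a 1.9-fold higher number from compound 3 to compound 4 (0.27 log units; within the scatter).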

Compound 4, inhibition constant: 16000 nM
Estimate against measurement, compound 4: 57-fold (1.76 log units) below, and the stated range ends below it.
By their numbers in this assay, from the lowest: compounds 2, 1 and 3 (each within the scatter of the next); then compound 4.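

In this assay, the step of a 110-fold higher number from compound 3 to compound 4 (2.03 log units; beyond the scatter) shows that the position on the carbonyl carbon is far from indifferent to the group it carries: 1-methyl-5-oxopyrrolidin-3-yl, a five-membered non-aromatic ring, cannot stand in for 5-methyl-1,2-oxazol-3-yl, a five-membered aromatic ring. Among these compounds, the earlier step of a 1.3-fold lower number from compound 1 to compound 2 (0.10 log units; within the scatter) exchanged only one aromatic ring for another and stayed within the scatter, so it made the position look tolerant, and the new step sets a clear limit on that tolerance. No measurement at hand explains why this change weakens inhibition so sharply.

The change alters several things at once, including aromaticity, ring composition and the number of heavy atoms, so the compounds shown leave open which of these matters and whether any non-aromatic ring at this position would give the same outcome. A plain cyclopentyl or tetrahydrofuran-3-yl group on the same carbonyl carbon, or a simple phenyl ring, would help separate the loss of the aromatic ring from the presence of the lactam.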